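Carbamoyl for pyridin-2-yl on the shared core: expected step

The source may hold more compounds than are shown below. What is called first, only, known or untested is meant among the compounds shown, and "the series" means these compounds.

Three compounds on the shared core differ only in the group on a nitrogen on an aromatic ring. In a functional assay on SF-268 cells (Homo sapiens) for cytotoxicity, read by MTT assay, with a stated time of 3 days (a higher number here means a weaker inhibitor, a lower number a stronger inhibitor), compound 1 `N#Cc1c(NN)nc(SCc2nc3ccccc3[nH]2)nc1-c1ccccc1` gives 2.77 nM, compound 2 `N#Cc1c(Nc2ccccc2)nc(SCc2nc3ccccc3[nH]2)nc1-c1ccccc1` gives 4.46 nM, and compound 3 `N#Cc1c(Nc2ccccn2)nc(SCc2nc3ccccc3[nH]2)nc1-c1ccccc1` gives 6.75 nM. Compound 3 stands with compound 2, at a 1.5-fold higher number from compound 2 to compound 3 (0.18 log units; within the scatter), and apart from compound 1 only, at a 2.4-fold higher number from compound 1 to compound 3 (0.39 log units; beyond the scatter).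

Compound 4 `N#Cc1c(NC(N)=O)nc(SCc2nc3ccccc3[nH]2)nc1-c1ccccc1` has carbamoyl in place of pyridin-2-yl on a nitrogen on an aromatic ring. Going by the values given here, no measured step makes this exact change, but all three steps at this place are small. The other is a 1.6-fold higher number from compound 1 to compound 2 (0.21 log units; within the scatter). Compound 4, like compound 1, has no ring on that nitrogen, which gives slight grounds for a number nearer the value of compound 1, 2.77 nM. One such compound is thin support, so no step beyond the scatter is expected in this assay. The estimated step is a 1.5-fold lower number from compound 3 to compound 4 (0.18 log units; within the scatter). For compound 4 the estimated value is 4.5 nM, with an expected range of 1.8 nM to 11 nM.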

Compound 4, half-maximal inhibitory concentration: 3.37 nM
Compound 4: middle estimate off by 1.3-fold (0.13 log units), on the high side, and the stated range covers the measured number.
By their numbers in this assay, from the lowest: compounds 1, 4, 2 and 3 (each within the scatter of the next, the first and the last beyond it).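

Carbamoyl is a group with no ring, and on a nitrogen on an aromatic ring in this assay it stays within the scatter of all three earlier groups: a 2.0-fold lower number from compound 3 to compound 4 (0.30 log units; within the scatter) and a 1.3-fold lower number from compound 2 to compound 4 (0.12 log units; within the scatter) and a 1.2-fold higher number from compound 1 to compound 4 (0.09 log units; within the scatter). A ring at this place is therefore not required to keep the number among those of compound 1 and compound 2, and the hydrogen-bond donor that enters with carbamoyl brings no step beyond the scatter. Nothing available explains why the numbers at this position lie so close together.

Still open, going by these compounds, is whether a longer alkyl chain or a carboxylic acid on that nitrogen would give a step beyond the scatter. The compounds shown also cannot tell whether this tolerance would persist with a different group elsewhere on the shared core.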